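This account rests on a few compounds, and the source may have more. Where it says the series, first, only, none or still open, it means among the compounds named here.

Measured so far:
compound 1, `S=c1[nH]ccn1Cc1ccccc1Cl`, 355000 nM
compound 2, `S=c1[nH]ccn1Cc1ccc(Br)cc1`, 115000 nM
compound 3, `Oc1ccc(Cn2cc[nH]c2=S)cc1Br`, 12000 nM

In an assay on isolated protein for inhibition of Dopamine beta-hydroxylase (Rattus norvegicus) (on this read-out higher numbers stand for weaker inhibition and lower numbers for stronger inhibition), compound 2 gives 115000 nM, the second highest of the three numbers. Compound 1 stands higher at 355000 nM, and compound 3 stands lower at 12000 nM; both gaps lie beyond the scatter. Compound 4, `O=[N+]([O-])c1ccc(Cn2cc[nH]c2=S)cc1`, is not yet measured. It differs from compound 2 in one place: nitro in place of bromo on an aromatic carbon. Going by the values given here, no pair of measured compounds shows this change, so the size of the step is open; compound 3 carries the bromo group together with a further group and gives a lower number, but nothing shows how nitro compares with bromo on its own. The expected step from compound 2 to compound 4 in this assay is a 1.2-fold lower number from compound 2 to compound 4 (0.06 log units; within the scatter), taken as not beyond the scatter. Compound 4 is estimated at 100000 nM, with a range of 30000 nM to 400000 nM.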

Compound 4, half-maximal inhibitory concentration: 52500 nM
Beside the measured number, compound 4's estimate is 1.9-fold (0.28 log units) above it, within the range that was stated.
By their numbers in this assay, from the lowest: compound 3; then compound 4; then compound 2; then compound 1.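

Going by these compounds alone, a first direct reading of this change comes from this assay: nitro in place of bromo on an aromatic carbon, para to a group of 7 heavy atoms, gives a 2.2-fold lower number from compound 2 to compound 4 (0.34 log units; beyond the scatter). The step is modest but lies beyond the scatter, so this position does not treat the two groups alike. No measurement at hand accounts for the step.

Open, as far as these compounds go, is how an amine or a carboxylic acid at this position would compare with nitro and bromo. Also open, from the compounds shown here alone, is whether the step holds on compounds carrying further groups on the ring.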